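Changing the Amide-Bound Aromatic Group of a p300 Inhibitor

This account rests on a few compounds, and the source may have more. Where it says the series, first, only, none or still open, it means among the compounds named here.

Compound 1 `O=C(Nc1ccc2[nH]nnc2c1)[C@H]1CCCN1C(=O)C1(c2cccc(Cl)c2)CCCC1` gives 20 nM in an assay on isolated protein for inhibition of histone acetyltransferase p300 (Homo sapiens), with a stated time of 60 min; a lower number here means a stronger inhibitor, a higher number a weaker inhibitor. Among the measured compounds shown here, that is the higher of the two numbers measured so far: compound 2 `N#Cc1ccc(C2(C(=O)N3CCC[C@@H]3C(=O)Nc3ccc4[nH]ncc4n3)CCC2)cc1` gives 0.251 nM, a much lower number, beyond the scatter, though it differs from compound 1 in more than one place. Compound 3 `O=C(Nc1ccc2[nH]ccc2n1)[C@H]1CCCN1C(=O)C1(c2cccc(Cl)c2)CCCC1` alters compound 1 on the amide-type nitrogen: a group of 9 heavy atoms (7 carbon, 2 nitrogen; one five-membered aromatic ring with 1 hetero atom, one six-membered aromatic ring with 1 hetero atom) in place of a group of 9 heavy atoms (6 carbon, 3 nitrogen; one five-membered aromatic ring with 3 hetero atoms, one six-membered aromatic ring of carbon only), on an amide-type nitrogen. For the measured compounds named here, no measured pair shows this change alone. A moderate step toward a lower number is expected, a 6.7-fold lower number from compound 1 to compound 3 (0.82 log units; beyond the scatter), since compound 2 shows a different group there alongside 0.251 nM. Compound 3 is estimated at 3 nM, within 0.5 nM to 20 nM.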

Compound 3, half-maximal inhibitory concentration: 0.159 nM
Compound 3: the middle estimate sits 19-fold (1.28 log units) above what was measured, and the stated range ends above it.
By their numbers in this assay, from the lowest: compounds 3 and 2 (each within the scatter of the next); then compound 1.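

With the rest of the molecule unchanged, replacing only the group on the amide-type nitrogen gives a 130-fold lower number from compound 1 to compound 3 (2.10 log units; beyond the scatter) in this assay, so this position alone can produce a large step. Compounds 1 and 2 could not show this, since they differ in more than one place. Nothing measured here explains the step. Both rings of the group change at once, so the compounds shown leave open which ring change matters. From the compounds shown here alone, how a simple phenyl group on this nitrogen would compare also remains open.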